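Three Anilides and One Untested Methoxy Analogue

The compounds below may be only part of what the source reports. "The series", "measured", "known", "first", "only" and "open" are said of these compounds alone.

Compound 1 `O=C(CCCCC(S)CCS)Nc1ccccc1` gives 6.38%
Compound 2 `O=C(CCCCC(S)CCS)Nc1ccc(Cl)cc1` gives 2.81%
Compound 3 `O=C(CCCCC(S)CCS)Nc1ccc(OC(F)(F)F)cc1` gives 0.56%

These values come from a functional assay on HO8910 cells (Homo sapiens) for inhibition, read by MTT assay, with a stated time of 24 h, tested at 1 ug/mL (a higher number here means more inhibition of growth at the concentration tested, a lower number less inhibition of growth), and all lie within the scatter of one another, so compound 3 cannot be told apart from the other two. The steps reaching it are a number 5.8 percentage points lower from compound 1 to compound 3 (within the scatter) and a number 2.3 percentage points lower from compound 2 to compound 3 (within the scatter) and the remaining one is a number 3.6 percentage points lower from compound 1 to compound 2 (within the scatter) and each stays within the scatter. Compound 4 `COc1ccc(NC(=O)CCCCC(S)CCS)cc1` is still unmeasured and carries methyl in place of trifluoromethyl on an oxygen on an aromatic ring in comparison with compound 3. For the measured compounds named here, no measured step is this exact change, and none of the three exceeds the scatter. A step beyond the scatter is therefore not expected, and the estimated step is a number 3.4 percentage points higher from compound 3 to compound 4 (within the scatter) in either direction at most. Compound 4 is estimated at 4% with an expected range of 0% to 12% in this measurement.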

Compound 4, percent growth inhibition at one concentration: 1.79%
The estimate for compound 4 lay 2.2 percentage points above the measured number, and the stated range covers the measured number.
By their numbers in this assay, from the lowest: compounds 3, 4, 2 and 1 (each within the scatter of the next).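

In this assay, putting methyl in place of trifluoromethyl on the oxygen on the aromatic ring gives a number 1.2 percentage points higher from compound 3 to compound 4 (within the scatter) and so adds one more change that stays within the scatter. Methoxy likewise gives a number 1 percentage points lower from compound 2 to compound 4 (within the scatter) and a number 4.6 percentage points lower from compound 1 to compound 4 (within the scatter) so that hydrogen, chloro, trifluoromethoxy and methoxy cannot be told apart at this concentration. No evidence bears on why these four compounds read alike. The compounds shown leave open whether an amine or a carboxylic acid in this place, or a longer chain on the oxygen, would give a step beyond the scatter.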